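Bromo in place of nitro on a shared core: series notes

This account rests on a few compounds, and the source may have more. Where it says the series, first, only, none or still open, it means among the compounds named here.

Measured so far, in a functional assay on HeLa cells (Homo sapiens) for antiproliferative activity, read by MTT assay, with a stated time of 48 h; a higher number here means a weaker inhibitor, a lower number a stronger inhibitor:
compound 1, `Cc1cc2c(c(=O)n1C)C(c1ccc(C(C)C)cc1)C(C#N)=C(N)O2`: > 100000 nM
compound 2, `Cc1cc2c(c(=O)n1C)C(c1cccc([N+](=O)[O-])c1)C(C#N)=C(N)O2`: 35000 nM
compound 3, `Cc1cc2c(c(=O)o1)C(c1cccc(Br)c1)C(C#N)=C(N)O2`: > 100000 nM

Among the measured compounds shown here, compound 2 gives 35000 nM in this assay, and this is the only number among the three measured compounds. Compound 1 gives > 100000 nM in this assay, a limit of the assay and not a number. Compound 3 gives > 100000 nM in this assay, likewise a limit. For the measured compounds named here, the measured set is therefore dominated by the limit of > 100000 nM in this assay, at which 2 of the 3 values shown sit, and compound 2 stands alone as the one compound with a quantified value.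

Compound 4, `Cc1cc2c(c(=O)n1C)C(c1cccc(Br)c1)C(C#N)=C(N)O2`, is not yet measured. It differs from compound 2 in one place: bromo in place of nitro on an aromatic carbon. Compound 3 also carries a bromo group on its aromatic ring, but on a different core, and it sits at the limit. Going by the values given here, no measured step connects a nitro group to a bromo group on the core of compound 2, so the expectation for compound 4 rests only on the spread of the three values shown.

The expected step is a 1.7-fold higher number from compound 2 to compound 4 (0.23 log units; within the scatter), toward weaker inhibition, with a real chance that only a limit is reported. In this assay compound 4 is estimated at 60000 nM, with an expected range from 20000 nM to 150000 nM.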

Compound 4, half-maximal inhibitory concentration: 6500 nM
Compound 4: middle estimate off by 9.2-fold (0.97 log units), on the high side; the measured number lies below the stated range.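

In this assay, bromo in place of nitro on an aromatic carbon, meta to a large group, gives a 5.4-fold lower number from compound 2 to compound 4 (0.73 log units; beyond the scatter), so this position on the shared core responds measurably to the group it carries, and a nitro group is not required there for a quantified value. Compound 3, which carries a bromo group on a different core, gives > 100000 nM, a limit of the assay and not a number. Among the compounds shown, the bromo group therefore gives a quantified value only on the core of compound 4, and steps involving a limit cannot be read, leaving this one pair as the only quantified comparison: the limit of > 100000 nM in this assay, at which 2 of the 4 values shown sit.

Still open, from the compounds shown here alone, is whether the lower number is particular to bromo or would also appear with a chloro group, a methoxy group or an amine at the same place on the shared core. The compounds shown also give no measured property that accompanies the step, so they cannot say why bromo and nitro differ here.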